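The compounds below may be only part of what the source reports. "The series", "measured", "known", "first", "only" and "open" are said of these compounds alone.

Measured so far in an ADME assay on the whole organism (Mus musculus, strain CD1) for pharmacokinetics, read by LC-MS, with a stated time of 24 h, at a dose of 5 mg/kg by the oral route (a lower number here means less compound in the circulation, a higher number more compound in the circulation at the dose given), are:
- compound 1 `O=C(O)Cn1nc(Cc2nc3cc(Cl)c(OCC(F)F)cc3[nH]2)c2ccccc2c1=O` with 82400 nM
- compound 2 `O=C(O)Cn1nc(Cn2cc3cc(OCC4CC4)c(Cl)cc3n2)c2ccccc2c1=O` with 3140000 nM
- compound 3 `CCC(C(=O)O)c1nn(Cc2cn3cc(OCC4CC4)c(Cl)cc3n2)c2ccccc2c1=O` with 2210000 nM

Compound 1 stands lowest of the three, with compound 2 and compound 3 both beyond the scatter above it. Compound 4 `O=C(O)Cn1nc(Cc2nc3cc(Cl)c(OCC4CC4)cc3[nH]2)c2ccccc2c1=O` keeps the core of compound 1 and carries cyclopropyl in place of difluoromethyl on a saturated chain carbon bound to an oxygen on an aromatic ring. For the measured compounds named here, no measured pair isolates this change. Compound 2 at 3140000 nM and compound 3 at 2210000 nM carry cyclopropylmethoxy on other structures, so they suggest only a direction. A rise is expected, with a 3.6-fold higher number from compound 1 to compound 4 (0.56 log units; beyond the scatter) as the estimated step, beyond the scatter but well short of those gaps. For compound 4 the estimated value is 300000 nM within an expected range from 70000 nM to 1300000 nM as a working figure.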

Compound 4, maximal plasma concentration: 98000 nM
For compound 4 the middle estimate is 3.1-fold (0.49 log units) above the measured one; the range from low to high includes it.
By their numbers in this assay, from the lowest: compounds 1 and 4 (each within the scatter of the next); then compounds 3 and 2 (each within the scatter of the next).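

In this assay the change to cyclopropyl on a saturated chain carbon bound to an oxygen on an aromatic ring gives a 1.2-fold higher number from compound 1 to compound 4 (0.08 log units; within the scatter) on the core of compound 1, so this pair does not separate difluoromethyl from cyclopropyl at this position. For the compounds shown here, the earlier compounds carried cyclopropylmethoxy only on other structures, and this pair is the first to isolate the change. Nothing at hand explains this result.

From the compounds shown here alone, it remains open whether an amine, a carboxylic acid or a longer chain at this position would shift the maximal plasma concentration beyond the scatter.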